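Dropping a Methyl from Compound 1: a Small Step Examined

The compounds below may be only part of what the source reports. "The series", "measured", "known", "first", "only" and "open" are said of these compounds alone.

This account concerns a set of small carboxamide-bearing compounds tested in an assay on isolated protein for inhibition of Nicotinamide N-methyltransferase (Homo sapiens), read by luminescence, with a stated time of 20 min; on this read-out lower numbers stand for stronger inhibition and higher numbers for weaker inhibition. Compound 1, `CNc1ncc(C(N)=O)c(C)n1`, carries a methyl group on its core. In this assay compound 1 gives only a limit of the assay, > 10000 nM, and no number. Compound 2, `NC(=O)c1cnc2c(c1)OCCN2`, likewise returns only a limit in this assay, > 10000 nM. Among the measured compounds shown here, compound 3, `CNc1cc(Cl)c(C(N)=O)cn1`, is the one member with a measured number: in this assay compound 3 gives 639 nM. Going by these compounds, compound 1 therefore stands at the limit of > 10000 nM in this assay, at which 2 of the 3 values shown sit, so its true potency is unknown beyond that ceiling.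

The step followed here leads from compound 1 to compound 4, `CNc1ncc(C(N)=O)cn1`. The change is hydrogen in place of methyl on an aromatic carbon: the methyl leaves an aromatic carbon of a six-membered aromatic ring with 2 nitrogen, ortho to a carbamoyl group and meta to a methylamino group, and a hydrogen enters in its place. No measured pair differing in one place exists among the compounds shown, so the size of this step cannot be read from the data. Because compound 1 sits at the limit of > 10000 nM in this assay, at which 2 of the 3 values shown sit, any gain below that ceiling would be invisible in the starting point, and a loss could not be seen at all.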

Compound 4, half-maximal inhibitory concentration: > 10000 nM
Compound 4 gave a limit, no number; the forecaster's own chance of this, stated with the estimate: 65%; the middle value lies beyond the limit too.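

Compound 4 gives only a limit of the assay, > 10000 nM. Compound 1 also gives only a limit, so no step from compound 1 to compound 4 can be read from these results: the limit of > 10000 nM in this assay, at which 3 of the 4 values shown sit.

The compounds shown leave open whether hydrogen in place of methyl on this aromatic carbon changes inhibition at all, and by how much.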